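The source may report more compounds than this note shows. Statements on the series, on what has been measured and on what is new or still open speak of the compounds shown alone.

Compound 1 `Nc1cc(N)c2nc(-c3ccccc3)c(NCc3ccc(Cl)c(Cl)c3)nc2c1`: 13500 nM
Compound 2 `CCOC(=O)[C@H](CCC(=O)O)NC(=O)c1ccc(Sc2nc3cc(N)cc(N)c3nc2-c2ccccc2)cc1`: 34700 nM
Compound 3 `Nc1cc(N)c2nc(-c3ccccc3)c(Sc3ccc(F)cc3)nc2c1`: 20400 nM

All three were tested in a functional assay on NCI-H322M cells (Homo sapiens) for inhibition, read by sulforhodamine B assay, with a stated time of 48 h; a higher number here means a weaker inhibitor of growth, a lower number a stronger inhibitor of growth. Compound 1 gives the lowest of the three numbers; compound 3 sits within the usual scatter of it, while compound 2 stands beyond the scatter with a higher number. Compound 4 `COc1ccc(CNc2nc3cc(N)cc(N)c3nc2-c2ccccc2)cc1OC` has not yet been measured. It differs from compound 1 in a single place: 3,4-dimethoxyphenyl in place of 3,4-dichlorophenyl on a saturated chain carbon bound to a nitrogen on an aromatic ring. Going by the values given here, no measured pair shows a change of this kind, so its effect is unknown here; no step beyond the scatter is expected in either direction in this assay. Compound 4 is expected to give about 18000 nM, within a range from 6000 nM to 55000 nM. This estimate means an expected step of a 1.3-fold higher number from compound 1 to compound 4 (0.12 log units; within the scatter).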

Compound 4, concentration for 50% growth inhibition: 22900 nM
Compound 4: the middle estimate sits 1.3-fold (0.10 log units) below what was measured; measured number inside the range.
By their numbers in this assay, from the lowest: compounds 1, 3, 4 and 2 (each within the scatter of the next, the first and the last beyond it).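

In this assay, going by these compounds alone, putting 3,4-dimethoxyphenyl in place of 3,4-dichlorophenyl gives (a 1.7-fold higher number from compound 1 to compound 4 (0.23 log units; within the scatter)), the first change at this place that can be read. The step stays within the scatter, so this exchange of two chlorines for two methoxy groups, which adds two hydrogen-bond acceptors, leaves growth inhibition effectively unchanged. No measured evidence bears on why.

Going by these compounds, whether an amine or a carboxylic acid on this phenyl ring would bring a step beyond the scatter remains open. The same holds for a longer chain to the ring.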